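Acyl chain variation on a cytidine-type ester series

This account rests on a few compounds, and the source may have more. Where it says the series, first, only, none or still open, it means among the compounds named here.

Measured compounds:
compound 1 `CCCCCCCCCCCCCCCCCC(=O)O[C@H]1[C@H](O)[C@H](n2ccc(N)nc2=O)O[C@@H]1CO` gives 0.13 ug/mL
compound 2 `CCCCCCCC/C=C\CCCCCCCCCCCC(=O)O[C@H]1[C@H](O)[C@H](n2ccc(N)nc2=O)O[C@@H]1CO` gives 0.16 ug/mL
compound 3 `CCCCCCCCCCCCCC(=O)O[C@H]1[C@H](O)[C@H](n2ccc(N)nc2=O)O[C@@H]1CO` gives 0.08 ug/mL

The three measured compounds share one core and differ only in the ester chain. In a functional assay on HeLa cells (Homo sapiens) for cytotoxicity, read by cell counting, with a stated time of 48 h (a lower number here means that less compound is needed, a higher number that more compound is needed for the effect), the numbers sit close together: all three steps among them are within the scatter, so no order among compound 1, compound 2 and compound 3 is claimed.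

The change from compound 1 to compound 2 is dec-1-en-1-yl in place of hexyl on a saturated chain carbon, ten or more bonds along the chain from a carbonyl carbon. Its step was a 1.2-fold higher number from compound 1 to compound 2 (0.09 log units; within the scatter). Compound 3 and compound 1 differ by hydrogen in place of butyl on a saturated chain carbon, ten or more bonds along the chain from a carbonyl carbon, with the step of a 1.6-fold lower number from compound 1 to compound 3 (0.21 log units; within the scatter); compound 2 to compound 3 reads a 2.0-fold lower number from compound 2 to compound 3 (0.30 log units; within the scatter).

Compound 4 `CCCCCCCC/C=C\CCCCCCCC(=O)O[C@H]1[C@H](O)[C@H](n2ccc(N)nc2=O)O[C@@H]1CO` is not yet measured. It differs from compound 3 by dec-1-en-1-yl in place of hexyl on a saturated chain carbon, seven bonds along the chain from a carbonyl carbon. This is the same kind of change as that from compound 1 to compound 2, but not the same: the two descriptions of the change show that the place along the chain, counted from the carbonyl carbon, differs between the two cases. Among the measured compounds shown here, only one earlier instance exists, so the expectation rests on it alone.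

The step from compound 3 to compound 4 is expected to be a 1.3-fold higher number from compound 3 to compound 4 (0.10 log units; within the scatter), because the earlier instance gave a 1.2-fold higher number from compound 1 to compound 2 (0.09 log units; within the scatter), a step within the scatter. Compound 4 is therefore estimated at 0.1 ug/mL, with a range from 0.05 ug/mL to 0.22 ug/mL.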

Compound 4, concentration for half-maximal effect: 0.06 ug/mL
The estimate for compound 4 lay 1.7-fold (0.22 log units) above the measured number, within the range that was stated.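

In this assay, dec-1-en-1-yl in place of hexyl, on a saturated chain carbon seven bonds along the chain from a carbonyl carbon, gives a 1.3-fold lower number from compound 3 to compound 4 (0.12 log units; within the scatter), and this step does not differ beyond the scatter from the earlier instance of the change on the other core: the same change on two cores in this assay, a 1.2-fold higher number (0.09 log units; within the scatter) from compound 1 to compound 2 and a 1.3-fold lower number (0.12 log units; within the scatter) from compound 3 to compound 4, 1.6-fold (0.22 log units) apart, within the scatter of two such steps. The two steps carry opposite signs, but each lies within the scatter, so the change can be carried between these two cores with no measurable shift in the number and no direction can be claimed; with only two instances, which also differ in their place along the chain, the notes cannot separate an influence of the core from one of the place, and they give no general rule for the series. Among the compounds shown here, the only step here beyond the scatter, a 2.2-fold lower number from compound 1 to compound 4 (0.34 log units; beyond the scatter), is modest, rests on a single pair, and sets no trend with the chain.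

The compounds shown leave open whether the same picture holds for a much shorter chain such as acetyl or for a longer chain than any of these. They also leave open what happens when the ester chain carries an amine or ends in a carboxylic acid.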